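Methoxy on the anilino ring of the thiazole amide series

A few compounds are considered here, and "the series" means these few. Any claim that something is new, unique, unknown or untested is made for them only; others in the source may bear on it.

Compound 1 `Cc1nc(SCC(=O)Nc2nc(-c3ccc(Cl)cc3)cs2)n(Nc2ccccc2)c1C` is one of two members of the series measured in a functional assay on BT-549 cells (Homo sapiens) for antiproliferative activity, read by sulforhodamine B assay, with a stated time of 48 h (on this read-out higher numbers stand for weaker inhibition of growth and lower numbers for stronger inhibition of growth), where compound 1 gives 7020 nM. Compound 2 `Cc1ccc(Nn2c(SCC(=O)Nc3nc(-c4ccccc4)cs3)nc(C)c2C)cc1`, which carries a methyl on its anilino ring and lacks the chloro on the thiazole aryl, gives 3180 nM in this assay. Of the two numbers, that of compound 1 is the higher, and the gap to compound 2 lies beyond the usual scatter. Compound 2 differs from compound 1 in two places, so the pair does not isolate either change.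

Compound 3 `COc1ccc(Nn2c(SCC(=O)Nc3nc(-c4ccc(Cl)cc4)cs3)nc(C)c2C)cc1` awaits measurement. Relative to compound 1 it carries methoxy in place of hydrogen on an aromatic carbon, so that anilino becomes (4-methoxyphenyl)amino while the chloro-substituted thiazole aryl is kept. Within the data shown here, no measured pair covers this change alone. Among the measured compounds shown here, the only guide is compound 2, whose value 3180 nM sits lower than that of compound 1 with a ring-substituted anilino group present. A modest step toward a lower number is therefore expected, a 1.6-fold lower number from compound 1 to compound 3 (0.19 log units; within the scatter), though it may fall within the scatter. For compound 3 the expected value is 4500 nM, with a range from 1500 nM to 13000 nM.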

Compound 3, concentration for 50% growth inhibition: 6460 nM
Compound 3: middle estimate off by 1.4-fold (0.16 log units), on the low side; measured number inside the range.
By their numbers in this assay, from the lowest: compound 2; then compounds 3 and 1 (each within the scatter of the next).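

In this assay, methoxy in place of hydrogen on an aromatic carbon, para to a large group, gives a 1.1-fold lower number from compound 1 to compound 3 (0.04 log units; within the scatter), so the anilino and (4-methoxyphenyl)amino forms with the chloro-substituted thiazole aryl cannot be told apart on this read-out. Among these compounds, this is the first step that isolates a single change, and it shows that this position takes methoxy with no separation from hydrogen. No measured evidence on hand speaks to what lies behind this result.

Still unresolved is which of the two differences carries the gap between compound 1 at 7020 nM and compound 2 at 3180 nM, the methyl on the anilino ring or the missing chloro on the thiazole aryl. Also open, going by these compounds, is how a carboxylic acid, an amine or a longer alkoxy chain at this same place would read in this assay, and whether the methoxy step would look the same without the chloro.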